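Swapping Pyridin-2-yl for 4-Chlorophenyl on a Shared Core

A few compounds are considered here, and "the series" means these few. Any claim that something is new, unique, unknown or untested is made for them only; others in the source may bear on it.

Compound 2 `C=C1C[C@]23C[C@@]1(O)CC[C@H]2c1ccc(OS(=O)(=O)c2ccc(C)cc2)c(C)c1[C@@H]3Cn1cc(-c2ccccn2)nn1` belongs to a small family built on one shared core. In a functional assay on SMMC-7721 cells (Homo sapiens) for cytotoxicity, read by MTT assay, with a stated time of 4 days (on this read-out lower numbers stand for stronger inhibition and higher numbers for weaker inhibition), compound 2 gives > 20000 nM, which is a limit of the assay and not a number. Among the compounds with values here, its only measured neighbour, compound 1 `C=C1C[C@]23C[C@@]1(O)CC[C@H]2c1ccc(OS(=O)(=O)c2ccc(C)cc2)c(C)c1[C@@H]3Cn1cc(-c2ccc(C)cc2)nn1`, carries 4-methylphenyl where compound 2 carries pyridin-2-yl. In this assay compound 1 likewise gives > 20000 nM, again a limit rather than a number. The step that the two limits leave unreadable from compound 1 to compound 2 is therefore unreadable, because both values sit at the limit of > 20000 nM in this assay, at which 2 of the 2 values shown sit, and compound 2 stands nowhere more precisely than at that limit.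

Compound 3 `C=C1C[C@]23C[C@@]1(O)CC[C@H]2c1ccc(OS(=O)(=O)c2ccc(C)cc2)c(C)c1[C@@H]3Cn1cc(-c2ccc(Cl)cc2)nn1` has not yet been measured. It differs from compound 2 by 4-chlorophenyl in place of pyridin-2-yl on an aromatic carbon. Within the data shown here, no measured step gives a readable size for such a change; the one known step, from 4-methylphenyl to pyridin-2-yl, cannot be read because both ends rest at the limit of > 20000 nM in this assay, at which 2 of the 2 values shown sit. With both measured neighbours reaching only the limit, compound 3 is expected to behave the same, so the expected step that the limit leaves unreadable from compound 2 to compound 3 is none beyond the scatter. Compound 3 is estimated at 30000 nM, between 15000 nM and 80000 nM, and most likely reported as a limit once more.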

Compound 3, half-maximal inhibitory concentration: > 20000 nM
Compound 3: no number, only a limit; the forecaster's own chance of this, stated with the estimate: 85%; the middle value lies beyond the limit too.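

Compound 3 also gives only a limit and not a number, so none of the steps among compound 1, compound 2 and compound 3 can be read: the limit of > 20000 nM in this assay, at which 3 of the 3 values shown sit.

The compounds shown leave open how far apart these three truly lie, and whether a readable number can be obtained in this assay with any other group at this place on the shared core.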